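The source may report more compounds than this note shows. Statements on the series, on what has been measured and on what is new or still open speak of the compounds shown alone.

Working notes on the series. In a functional assay on DU-145 cells (Homo sapiens) for inhibition, read by trypan blue exclusion, with a stated time of 96 h (on this read-out higher numbers stand for weaker inhibition of growth and lower numbers for stronger inhibition of growth), compound 1 (`O=C(/C(=C\c1ccc(O)c([N+](=O)[O-])c1)SCc1ccc(Cl)cc1)c1ccc(Cl)cc1`) gives 10000 nM, level with compound 2 (`Cc1ccc(C)c(/C=C(/SCc2ccc(Cl)cc2)C(=O)c2ccc(Cl)cc2)c1`) at 10000 nM and compound 3 (`Cc1cc(C)cc(/C=C(/SCc2ccc(Cl)cc2)C(=O)c2ccc(Cl)cc2)c1`) at 10000 nM.

Compound 4 (`O=C(/C(=C\c1ccc(O)c([N+](=O)[O-])c1)Sc1ccccc1Br)c1ccc(Cl)cc1`) carries a change at a different place, with 2-bromophenyl in place of 4-chlorobenzyl on a sulfur.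

The measured steps all concern the group on the double-bonded chain carbon: no change at the digits printed from compound 1 to compound 2 (within the scatter), no change at the digits printed from compound 1 to compound 3 (within the scatter) and no change at the digits printed from compound 2 to compound 3 (within the scatter). None of them goes beyond the scatter, but none alters the group on the sulfur, so they bear on this change only indirectly. Among the compounds with values here, the series holds no measured step at the sulfur. No step beyond the scatter is therefore expected in this assay, and no direction is favoured, although the uncertainty is wide.

The estimated step is a 1.3-fold lower number from compound 1 to compound 4 (0.10 log units; within the scatter). For compound 4 the expected value is 8000 nM, with an estimated range of 2000 nM to 20000 nM.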

Compound 4, concentration for 50% growth inhibition: 25000 nM
Estimate against measurement, compound 4: 3.1-fold (0.49 log units) below; measured number above the stated range.
By their numbers in this assay, from the lowest: compounds 1, 2 and 3 (each within the scatter of the next); then compound 4.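

Within the data shown here, the group on the sulfur is the first place where a step in this assay goes beyond the scatter: 2-bromophenyl in place of 4-chlorobenzyl gives a 2.5-fold higher number from compound 1 to compound 4 (0.40 log units; beyond the scatter), a modest weakening of growth inhibition. The steps on the double-bonded chain carbon all stayed within the scatter, so among the compounds shown, only the change on the sulfur moves the number beyond it. Nothing at hand accounts for this step.

This single step does not separate the change from chlorine to bromine from the change from benzyl to phenyl. On these data alone, it also remains open how the number would respond to other groups on the sulfur, such as 2-chlorophenyl, 2-bromobenzyl, or a longer chain such as 2-phenylethyl.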